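The compounds below may be only part of what the source reports. "The series", "measured", "known", "first", "only" and "open" are said of these compounds alone.

Compound 1 `COc1ccc(-c2oc3c(CC=C(C)C)c(OCC(=O)O)cc(O)c3c(=O)c2OCC(=O)O)cc1` is the starting point. In a functional assay on MDA-MB-435S cells (Homo sapiens) for cytotoxicity, read by MTT assay (on this read-out lower numbers stand for stronger inhibition and higher numbers for weaker inhibition), compound 1 gives > 100000 nM, which is a limit of the assay rather than a number (the limit of > 100000 nM in this assay, at which 1 of the 2 values shown sits). Compound 2 `COc1ccc(-c2oc3c(CC=C(C)C)c(OCCCOC(=O)CCCC(=O)O)cc(O)c3c(=O)c2OCCCOC(=O)CCCC(=O)O)cc1` gives 8100 nM in this assay. Compound 3 `COc1ccc(-c2oc3c(CC=C(C)C)c(OCC(=O)O)cc(O)c3c(=O)c2O)cc1` differs from compound 1 by hydrogen in place of carboxymethyl on an oxygen on an aromatic ring. Among the measured compounds shown here, no step between two measured compounds is available, so the size of this change is open. Compound 3 is expected to move by an at least 2.0-fold lower number from compound 1 to compound 3 (0.30 log units; that floor lies within the scatter) toward stronger inhibition. Compound 3 is estimated at 50000 nM, with a range from 15000 nM to 200000 nM.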

Compound 3, half-maximal inhibitory concentration: 13500 nM
Compound 3: middle estimate off by 3.7-fold (0.57 log units), on the high side, outside the stated range (below it).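

In this assay, among the compounds shown here, hydrogen in place of carboxymethyl on an oxygen on an aromatic ring gives an at least 7.4-fold lower number from compound 1 to compound 3 (0.86 log units; beyond the scatter) and so puts a first size on a change at this position, with the other carboxymethyl group left in place. Removing this one group is enough to give a measurable value. The full size of the step cannot be read because compound 1 stands at a limit of the assay, not at a number: the limit of > 100000 nM in this assay, at which 1 of the 3 values shown sits.

Going by these compounds, it remains open whether a methyl or an aminoethyl group on this oxygen would read like hydrogen or like carboxymethyl. On these data alone, the same replacement at the other carboxymethyl group of compound 1 also remains open.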